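Nitro for fluoro in a fused-ring aryl sulfonamide series

The compounds below may be only part of what the source reports. "The series", "measured", "known", "first", "only" and "open" are said of these compounds alone.

Measured so far in a functional assay on aorta (Rattus norvegicus, strain Wistar) for inhibition; on this read-out lower numbers stand for an effect already at smaller amounts and higher numbers for an effect only at larger amounts of compound:
compound 1 `CC1(C)CC(NC(=O)C2=NS(=O)(=O)c3ccccc3N2)c2cc(F)ccc2O1` — limit of the assay, > 30000 nM
compound 2 `Cc1ccc2c(c1)S(=O)(=O)N=C(C(=O)NC1CC(C)(C)Oc3ccc(F)cc31)N2` — limit of the assay, > 30000 nM
compound 3 `Cc1ccc2c(c1)S(=O)(=O)N=C(C(=O)NC1CC(C)(C)Oc3ccc(Br)cc31)N2` — limit of the assay, > 30000 nM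

Compound 1 stands only as a limit in this assay, with no number behind it. The step from compound 1 to compound 2, methyl in place of hydrogen on an aromatic carbon, is a step that the two limits leave unreadable from compound 1 to compound 2. The step from compound 2 to compound 3, bromo in place of fluoro, is a step that the two limits leave unreadable from compound 2 to compound 3. Among the compounds with values here, all three values sit at the limit of > 30000 nM in this assay, at which 3 of the 3 values shown sit, so no measured step tells how a change at this aromatic carbon moves the read-out.

Compound 4 `CC1(C)CC(NC(=O)C2=NS(=O)(=O)c3ccccc3N2)c2cc([N+](=O)[O-])ccc2O1` differs from compound 1 by nitro in place of fluoro on an aromatic carbon. Within the data shown here, no measured step bears on it; the expected step in this assay is a number no higher from compound 1 to compound 4 (the limit leaves the size open). For compound 4 the estimated value is 30000 nM, between 10000 nM and 100000 nM.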

Compound 4, half-maximal effective concentration: > 30000 nM
Compound 4 gave a limit, no number (the forecaster's own chance of this, stated with the estimate: 85%); the middle value sits exactly at the limit.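

Compound 1 and compound 4 both stand only as limits in this assay, and no step can be read from the swap of nitro for fluoro: the limit of > 30000 nM in this assay, at which 4 of the 4 values shown sit.

The compounds shown leave open whether any change at this aromatic carbon moves the read-out at all.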